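A pyrazolyl swap on the core of compound 1

A few compounds are considered here, and "the series" means these few. Any claim that something is new, unique, unknown or untested is made for them only; others in the source may bear on it.

Among the compounds with values here, in a physicochemical assay for solubility (a lower number here means a less soluble compound, a higher number a more soluble compound), compound 1 `O=S(=O)(Nc1nccs1)c1ccc2c(c1)OCC[C@H]2c1ccc(C(F)(F)F)cc1-n1ccnn1` gives 154000 nM and stands highest of the three numbers measured so far. Compound 3 `O=S(=O)(Nc1nccs1)c1ccc2c(c1)OCC[C@@H]2c1ccc(C(F)(F)F)cc1-c1ccc(F)cc1` gives 39000 nM as the nearest and compound 2 `Cn1nccc1-c1cc(C(F)(F)F)ccc1[C@H]1CCOc2cc(S(=O)(=O)Nc3ccc(F)cn3)ccc21` gives 29000 nM as the furthest, both beyond the scatter from compound 1. Compound 4 `Cn1nccc1-c1cc(C(F)(F)F)ccc1[C@@H]1CCOc2cc(S(=O)(=O)Nc3nccs3)ccc21` has yet to be measured. Compared with compound 1, it carries 1-methyl-1H-pyrazol-5-yl in place of 1H-1,2,3-triazol-1-yl on an aromatic carbon on an aromatic carbon, ortho to a large group and meta to a trifluoromethyl group. Within the data shown here, no measured pair isolates this change, so any expectation rests on indirect evidence. Compound 2 also carries 1-methyl-1H-pyrazol-5-yl and gives 29000 nM in this assay but differs from compound 4 elsewhere as well. A lower number is therefore expected, and the estimated step is a 2.6-fold lower number from compound 1 to compound 4 (0.41 log units; beyond the scatter) and lies beyond the scatter. Compound 4 is estimated at 60000 nM with 22000 nM to 150000 nM as the expected range.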

Compound 4, solubility: 65000 nM
Beside the measured number, compound 4's estimate is 1.1-fold (0.03 log units) below it; measured number inside the range.
By their numbers in this assay, from the lowest: compounds 2, 3 and 4 (each within the scatter of the next, the first and the last beyond it); then compound 1.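

Within the data shown here, compound 4 gives the first direct reading at this position, on an aromatic carbon ortho to a large group and meta to a trifluoromethyl group: measured in this assay the swap to 1-methyl-1H-pyrazol-5-yl from 1H-1,2,3-triazol-1-yl gives a 2.4-fold lower number from compound 1 to compound 4 (0.37 log units; beyond the scatter) as a modest step. Among these compounds, the earlier compounds held no pair that isolated this change, so this is the first sign that the group at this position alone can move the number beyond the scatter. No measurement at hand bears on why the number falls.

The compounds shown leave open whether an amine or a carboxylic acid on this aromatic carbon would move the number further, or in which direction. They also leave open whether the same swap gives a step of like size in compounds that differ elsewhere.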